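Reducing the Ketone in a Hydroxamic Acid Series

The source may hold more compounds than are shown below. What is called first, only, known or untested is meant among the compounds shown, and "the series" means these compounds.

Three compounds sharing one core were tested in an assay for binding affinity to histone acetyltransferase KAT2B (Homo sapiens), tested at 25 uM; a lower number here means that the compound stabilises the target less, a higher number that the compound stabilises the target more against heat. Compound 1 `Cc1noc(C)c1-c1cc(OCCCCCC(=O)NO)cc(C(=O)c2ccccc2)c1` gives 0.28 degrees C, compound 2 `Cc1noc(C)c1-c1cc(OCCCCCCC(=O)NO)cc(C(=O)c2ccccc2)c1` gives 1.04 degrees C, and compound 3 `Cc1noc(C)c1-c1cc(OCCCCCCCC(=O)NO)cc(C(=O)c2ccccc2)c1` gives -0.31 degrees C. Compound 2 stands at the top of these three numbers, though only its gap to compound 3 is beyond the scatter: a number 0.76 degrees C higher from compound 1 to compound 2 (within the scatter), while a number 1.4 degrees C lower from compound 2 to compound 3 (beyond the scatter). Compound 4 `Cc1noc(C)c1-c1cc(OCCCCCCC(=O)NO)cc(C(O)c2ccccc2)c1` differs from compound 2 by hydroxy(phenyl)methyl in place of benzoyl on an aromatic carbon. Within the data shown here, none of the measured steps touches this position; each of them only lengthens the chain, and all stay small. The new change is therefore expected to leave the number roughly where it is, with a number 0.54 degrees C lower from compound 2 to compound 4 (within the scatter) not beyond the scatter. Compound 4 is thus estimated at 0.5 degrees C, within -0.8 degrees C to 1.8 degrees C.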

Compound 4, shift of the target's melting temperature: 0.35 degrees C
The estimate for compound 4 lay 0.15 degrees C above the measured number; measured number inside the range.
By their numbers in this assay, from the lowest: compounds 3, 1, 4 and 2 (each within the scatter of the next, the first and the last beyond it).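

In this assay, among these compounds, the replacement of benzoyl by hydroxy(phenyl)methyl on an aromatic carbon gives a number 0.69 degrees C lower from compound 2 to compound 4 (within the scatter) and is the first measured change at this position. The swap keeps the same heavy-atom count and the aromatic ring, loses the double bond outside the ring and adds a hydrogen-bond donor, yet the number does not move beyond the scatter. Nothing at hand speaks to the reason for this result.

As far as these compounds go, whether an amine or a carboxylic acid at this position would move the number beyond the scatter remains open. Also open, from the compounds shown here alone, is whether hydroxy(phenyl)methyl behaves the same way on the chains of compound 1 and compound 3.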